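The source may report more compounds than this note shows. Statements on the series, on what has been measured and on what is new or still open speak of the compounds shown alone.

Of the compounds shown here, three built on a shared core have been measured in a functional assay on HCT-116 cells (Homo sapiens) for cytotoxicity, read by sulforhodamine B assay, with a stated time of 48 h; on this read-out higher numbers stand for weaker inhibition and lower numbers for stronger inhibition. Compound 1 `COc1ccccc1/C=C/C(=O)/C=C/c1ccc(OCc2cn(CCOc3cc(=O)oc4ccccc34)nn2)c(OC)c1` gives 9490 nM. Compound 2 `COc1cc(/C=C/C(=O)/C=C/c2cc(OC)c(OC)c(OC)c2)ccc1OCc1cn(CCOc2cc(=O)oc3ccccc23)nn1` gives 2210 nM, the lowest of the three numbers; compound 1 sits a clear step above it, and compound 3 further still. Compound 3 `COc1cc(/C=C/C(=O)/C=C/c2cccc3ccccc23)ccc1OCc1cn(CCCOc2cc(=O)oc3ccccc23)nn1`, which also carries a different chain elsewhere in the core, gives 10400 nM. Within the data shown here, only one pair differs in a single place: a 4.3-fold lower number from compound 1 to compound 2 (0.63 log units; beyond the scatter).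

Compound 4 `COc1ccc(/C=C/C(=O)/C=C/c2ccc(OCc3cn(CCOc4cc(=O)oc5ccccc45)nn3)c(OC)c2)cc1` derives from compound 2 by the change (4-methoxyphenyl in place of 3,4,5-trimethoxyphenyl on a double-bonded chain carbon bound to a double-bonded chain carbon). The step from compound 1 to compound 2 is the one that bears on this, since it too exchanged the aryl group on that chain carbon, and there the move to the 3,4,5-trimethoxyphenyl group brought a modest fall beyond the scatter. Reversing toward a single methoxy group, though at a different ring position than in compound 1, is therefore expected to send the number back up, by a step of about a 2.5-fold higher number from compound 2 to compound 4 (0.40 log units; beyond the scatter), with the 4-methoxyphenyl group itself untested and so the uncertainty wide. In this assay compound 4 is expected to give 5500 nM, within a range of 2000 nM to 14000 nM.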

Compound 4, half-maximal inhibitory concentration: 9290 nM
The estimate for compound 4 lay 1.7-fold (0.23 log units) below the measured number, within the range that was stated.
By their numbers in this assay, from the lowest: compound 2; then compounds 4, 1 and 3 (each within the scatter of the next).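

In this assay the exchange of the 3,4,5-trimethoxyphenyl group for 4-methoxyphenyl on a double-bonded chain carbon bound to a double-bonded chain carbon gives a 4.2-fold higher number from compound 2 to compound 4 (0.62 log units; beyond the scatter) and so shows that a second aryl group with a single methoxy group also stands clearly apart from compound 2. The two single-methoxy groups cannot be told apart at this place, with a 1.0-fold lower number from compound 1 to compound 4 (0.01 log units; within the scatter) in the exchange of 2-methoxyphenyl for 4-methoxyphenyl, so among these three compounds, which differ only in this group, moving the single methoxy group between those two ring positions makes no readable difference and only the 3,4,5-trimethoxyphenyl group departs from the others. Nothing available here accounts for this difference.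

The compounds shown leave open whether all three methoxy groups are needed, since a 3,4-dimethoxyphenyl group, a 3-methoxyphenyl group and a plain phenyl group are not among them. Compound 3 differs from the others in more than one place, so its steps cannot be read, and the effect of its longer chain remains unseparated from that of its aryl group.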